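A few compounds are considered here, and "the series" means these few. Any claim that something is new, unique, unknown or untested is made for them only; others in the source may bear on it.

The series shares one core and varies only the group on the amine nitrogen in the ring. Compound 1 `CCCCNc1nc(N)nc2c1CN(Cc1ccccc1Cl)CC2` gives 0.05 uM in an assay on HEK293 cells for agonist activity at Toll-like receptor 8 (Homo sapiens), read by a luciferase reporter, with a stated time of 6 h; a higher number here means that more compound is needed for the effect, a lower number that less compound is needed. Compound 2 `CCCCNc1nc(N)nc2c1CN(C(=O)CC)CC2` gives 0.4 uM in this assay. The step of an 8.0-fold higher number from compound 1 to compound 2 (0.90 log units; beyond the scatter) is the smaller of the two measured steps. Compound 3 `CCCCNc1nc(N)nc2c1CN(C(=O)c1cnc(C)cn1)CC2` gives 6.8 uM in this assay, and the step of a 17-fold higher number from compound 2 to compound 3 (1.23 log units; beyond the scatter) is the larger of the two measured steps. Compound 3 therefore stands at the highest number of the three measured, with compound 2 nearest and compound 1 furthest.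

Compound 4 `CCCCNc1nc(N)nc2c1CN(C(=O)c1cc(C)on1)CC2` differs from compound 3 in one place: 5-methyl-1,2-oxazol-3-yl in place of 5-methylpyrazin-2-yl on a carbonyl carbon Both groups are aromatic rings with two hetero atoms, attached through the same carbonyl to the same ring nitrogen. For the measured compounds named here, no measured step exchanges one such aromatic ring for another on this carbonyl; the nearest comparison is a 17-fold higher number from compound 2 to compound 3 (1.23 log units; beyond the scatter), which shows how strongly this position can move the number, but it replaces ethyl rather than an aromatic ring. The number for compound 4 is therefore expected to stay close to that of compound 3, with the step of a 1.4-fold lower number from compound 3 to compound 4 (0.13 log units; within the scatter) expected to fall within or only just beyond the scatter. Compound 4 is estimated at 5 uM in this assay, within a range of 1.5 uM to 15 uM.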

Compound 4, minimum effective concentration: 0.4 uM
Beside the measured number, compound 4's estimate is 13-fold (1.10 log units) above it; measured number outside the range, below it.
By their numbers in this assay, from the lowest: compound 1; then compounds 2 and 4 (each within the scatter of the next); then compound 3.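

Exchanging one aromatic ring with two hetero atoms for another on this carbonyl carbon gives a 17-fold lower number from compound 3 to compound 4 (1.23 log units; beyond the scatter) in this assay, so the high number of compound 3 goes with the 5-methylpyrazin-2-yl group and not with an aromatic ring on this carbonyl as such. Set against the ethyl group, the 5-methyl-1,2-oxazol-3-yl group gives no change at the digits printed from compound 2 to compound 4 (within the scatter), and set against the 2-chlorobenzyl group, the (5-methyl-1,2-oxazol-3-yl)carbonyl group gives an 8.0-fold higher number from compound 1 to compound 4 (0.90 log units; beyond the scatter), which leaves the 2-chlorobenzyl compound with the lowest number of the four in this assay. Nothing at hand accounts for the gap between the two aromatic rings.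

Open, on these data alone, is where a plain phenyl or a pyridin-2-yl group on this carbonyl would fall in this assay, and whether the methyl group on either aromatic ring contributes to the gap. Also open, as far as these compounds go, is whether the low number of the 2-chlorobenzyl compound depends on the chlorine or on the lack of a carbonyl, which a plain benzyl or a 2-chlorobenzoyl group on the same ring nitrogen would help to separate.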